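Swapping a Benzyl Ether Side Group for a Fluorophenyl Carbonyl

A few compounds are considered here, and "the series" means these few. Any claim that something is new, unique, unknown or untested is made for them only; others in the source may bear on it.

Compound 1, `Cc1noc(C)c1COC1CC(=O)Nc2c1c(C)nn2-c1ncnc2nc[nH]c12`, gives 5 nM in a functional assay on HEK293 cells for agonist activity at G-protein coupled receptor 39 (Homo sapiens), read by scintillation proximity assay and inositol phosphate accumulation, with a stated time of 75 min, in the presence of a further agent that is not named here; on this read-out higher numbers stand for an effect only at larger amounts of compound and lower numbers for an effect already at smaller amounts.
Compound 2, `Cc1nn(-c2ncnc3nc[nH]c23)c2c1C(OCCc1ccccc1)CC(=O)N2`, gives 3 nM in this assay.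
Compound 3, `Cc1nn(-c2ncnc3nc[nH]c23)c2c1C(OCc1ccccc1Cl)CC(=O)N2`, gives 2 nM in this assay.

Compound 3 carries the lowest of the three numbers. Its gap to compound 2, a 1.5-fold lower number from compound 2 to compound 3 (0.18 log units; within the scatter), lies within the scatter, so the two cannot be ranked; its gap to compound 1, a 2.5-fold lower number from compound 1 to compound 3 (0.40 log units; beyond the scatter), is modest but beyond it.

Compound 4, `Cc1nn(-c2ncnc3nc[nH]c23)c2c1C(OC(=O)c1ccc(F)cc1)CC(=O)N2`, differs from compound 3 in one place: (4-fluorophenyl)carbonyl in place of 2-chlorobenzyl on an oxygen on a saturated carbon. The three measured steps all exchange one ring-bearing group for another on the same oxygen, and all were small: a 1.7-fold lower number from compound 1 to compound 2 (0.22 log units; within the scatter), a 2.5-fold lower number from compound 1 to compound 3 (0.40 log units; beyond the scatter) and a 1.5-fold lower number from compound 2 to compound 3 (0.18 log units; within the scatter). Among the compounds with values here, none of them, however, placed a carbonyl between the oxygen and the ring, so the new group has no direct precedent here. Given that every group tried so far kept the number within a narrow band, the expectation is a small step toward a higher number in this assay, possibly still within the scatter. Compound 4 is therefore expected to give about 5 nM, estimated between 1.5 nM and 20 nM. That estimate means an expected 2.5-fold higher number from compound 3 to compound 4 (0.40 log units; beyond the scatter).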

Compound 4, half-maximal effective concentration: 4 nM
Compound 4: the middle estimate sits 1.3-fold (0.10 log units) above what was measured; the measured number falls inside the stated range.
By their numbers in this assay, from the lowest: compounds 3, 2, 4 and 1 (each within the scatter of the next, the first and the last beyond it).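

In this assay, putting a carbonyl directly on this oxygen leaves the number in the same narrow band, with a 2.0-fold higher number from compound 3 to compound 4 (0.30 log units; within the scatter) and a 1.3-fold higher number from compound 2 to compound 4 (0.12 log units; within the scatter) and also a 1.3-fold lower number from compound 1 to compound 4 (0.10 log units; within the scatter) all read as no real difference. The earlier compounds shown here all had a saturated carbon on this oxygen, so compound 4 adds a new kind of link that is tolerated here, and it cannot be ranked against any of the other three, even though compound 1 and compound 3 lie apart. Nothing available here explains this tolerance.

This step changes the carbonyl and the ring's halogen together, so the two cannot be separated without a 4-fluorobenzyl group on the same oxygen. From the compounds shown here alone, whether the oxygen itself can be replaced, for example by an amine, also remains open.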